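Fluorine Moved to the Sulfonyl Side of the Ring

This account rests on a few compounds, and the source may have more. Where it says the series, first, only, none or still open, it means among the compounds named here.

Compound 1 `CC(C)(C)OC(=O)N1CCC2(CC1)CC(CCCOc1ccc(S(C)(=O)=O)cc1)C2` serves as the reference of this small set. Going by the values given here, in a functional assay on cells for agonist activity at Glucose-dependent insulinotropic receptor (Homo sapiens), read by HTRF and cAMP accumulation, with a stated time of 30 min (a higher number here means that more compound is needed for the effect, a lower number that less compound is needed), compound 1 gives 14 nM, the lowest of the two numbers measured so far, though its nearest neighbour lies within the scatter. Compound 2 `CC(C)(C)OC(=O)N1CCC2(CC1)CC(CCCOc1ccc(S(C)(=O)=O)cc1F)C2` carries a fluorine on the aromatic ring, and in this assay compound 2 gives 25 nM. The step of a 1.8-fold higher number from compound 1 to compound 2 (0.25 log units; within the scatter) stays within the usual scatter. Compound 3 `CC(C)(C)OC(=O)N1CCC2(CC1)CC(CCCOc1ccc(S(C)(=O)=O)c(F)c1)C2` has not been measured. It differs from compound 1 by fluoro in place of hydrogen on an aromatic carbon. Among the compounds with values here, the only step that bears on this change is the one from compound 1 to compound 2, a fluoro for hydrogen on the same ring at a different carbon, and it did not move the number beyond the scatter. A small step is therefore expected in this assay, if anything a modest rise: a 1.4-fold higher number from compound 1 to compound 3 (0.15 log units; within the scatter). Compound 3 is estimated at 20 nM, within a range from 7 nM to 60 nM.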

Compound 3, half-maximal effective concentration: 9 nM
Compound 3: the middle estimate sits 2.2-fold (0.35 log units) above what was measured, within the range that was stated.
By their numbers in this assay, from the lowest: compounds 3, 1 and 2 (each within the scatter of the next, the first and the last beyond it).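

With fluoro on the aromatic carbon ortho to the methylsulfonyl group, a 1.6-fold lower number from compound 1 to compound 3 (0.19 log units; within the scatter) in this assay stays within the scatter, so this carbon takes the fluorine without a clear change. What compound 2 alone could not show is that the place of the fluorine on the ring can separate two compounds: compound 3 at 9 nM and compound 2 at 25 nM lie beyond the scatter of each other, although each lies within the scatter of compound 1. Nothing on hand accounts for this difference between the two ring carbons.

From the compounds shown here alone, whether chloro, methoxy or a nitrile on this same carbon would keep the number there remains open, as does the effect of a second fluorine on the ring. Also open, going by these compounds, is what happens when the methylsulfonyl group itself gives way to a carboxylic acid or an amide with the fluorine kept in place.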